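Moving a Hydroxymethyl Around a Pyridine Ring

The compounds below may be only part of what the source reports. "The series", "measured", "known", "first", "only" and "open" are said of these compounds alone.

Of the compounds shown here, two with a shared core have been measured in an assay on cells for binding affinity to Orexin receptor type 2 (Homo sapiens), read by radioligand binding; a lower number here means a stronger inhibitor, a higher number a weaker inhibitor. Compound 1 `Cc1ccc(-n2nccn2)c(C(=O)N2C[C@H](C#Cc3ccc(F)cn3)CC[C@H]2C)c1` gives 1.1 nM. Going by the values given here, compound 2 `Cc1ccc(-n2nccn2)c(C(=O)N2C[C@H](C#Cc3cc(CO)ccn3)CC[C@H]2C)c1` gives 42 nM, the higher of the two numbers, and its only neighbour is compound 1: the single measured step, a 38-fold higher number from compound 1 to compound 2 (1.58 log units; beyond the scatter), is a large one, but it swaps both the kind of group and the position on the pyridine at once.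

Compound 3 `Cc1ccc(-n2nccn2)c(C(=O)N2C[C@H](C#Cc3ccc(CO)cn3)CC[C@H]2C)c1` keeps every atom of compound 2 and differs only in how they are joined: 5-(hydroxymethyl)pyridin-2-yl in place of 4-(hydroxymethyl)pyridin-2-yl on a triple-bonded carbon. Among the compounds with values here, no measured step isolates this move of the hydroxymethyl alone, so the one step on record does not speak directly to it. What is known is that compound 3 carries its hydroxymethyl at the same position where compound 1 carries its fluorine, and compound 1 gives the low number 1.1 nM. On that slender ground a modest step to a lower number is expected, a 2.1-fold lower number from compound 2 to compound 3 (0.32 log units; beyond the scatter), with a wide margin either way. Compound 3 is therefore estimated at 20 nM, in a range from 5 nM to 100 nM.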

Compound 3, inhibition constant: 130 nM
For compound 3 the middle estimate is 6.5-fold (0.81 log units) below the measured one, and the stated range ends below it.
By their numbers in this assay, from the lowest: compound 1; then compound 2; then compound 3.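

Moving the hydroxymethyl alone, with nothing else changed, gives a 3.1-fold higher number from compound 2 to compound 3 (0.49 log units; beyond the scatter) in this assay, so where this group sits on the pyridine matters in its own right, and the 4-(hydroxymethyl)pyridin-2-yl arrangement gives the lower number of the two. Keeping the place on the ring fixed and changing only the group gives a much larger step, a 120-fold higher number from compound 1 to compound 3 (2.07 log units; beyond the scatter), which shows that replacing fluoro with hydroxymethyl on that aromatic carbon outweighs the move around the ring, a separation that the single mixed step from the earlier pair could not provide. No supporting data here explain why either change raises the number.

The compounds shown leave open whether a fluorine placed where compound 2 carries its hydroxymethyl would follow the same order, so it remains unknown whether the effect of position holds for groups other than hydroxymethyl. They also leave open whether the large step belongs to hydroxymethyl specifically or would recur with a methyl, a methoxymethyl, an aminomethyl or a carboxylic acid on the same aromatic carbon.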